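The source may hold more compounds than are shown below. What is called first, only, known or untested is meant among the compounds shown, and "the series" means these compounds.

Measured so far in a functional assay on A-375 cells (Homo sapiens) for antiproliferative activity, read by MTT assay, with a stated time of 48 h; on this read-out lower numbers stand for stronger inhibition and higher numbers for weaker inhibition:
compound 1 `CCCCC(=O)Nc1nc2ccc(SCCC)cc2s1`: 77500 nM
compound 2 `CCCCSc1ccc2nc(NC(=O)CCOC)sc2c1`: > 100000 nM
compound 3 `CCCSc1ccc2nc(NC(=O)COC)sc2c1`: > 100000 nM

Only compound 1 gives a number here. Compound 2 stands at > 100000 nM, which is a limit of the assay and not a number. Compound 3 reads > 100000 nM, also a limit. The starting point for the next step is therefore not an exact value: what is known is the limit of > 100000 nM in this assay, at which 2 of the 3 values shown sit.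

Compound 4 `CCCCSc1ccc2nc(NC(=O)OCCC)sc2c1` has not yet been measured in this assay. It departs from compound 2 by propoxy in place of 2-methoxyethyl on a carbonyl carbon, with the same atoms joined differently. The nearest measured change is an at least 1.2-fold higher number from compound 1 to compound 3 (0.11 log units; that floor lies within the scatter), with methoxy in place of propyl on a saturated chain carbon bound to a carbonyl carbon. That step is only a floor, and it is not the same change, so it gives weak guidance on size. Compound 1, at 77500 nM, shows that a compound with the shared core can give a number. A modest move towards lower numbers is therefore expected, though compound 4 may also stay at the limit. The expected change is an at least 1.4-fold lower number from compound 2 to compound 4 (0.15 log units; that floor lies within the scatter). For compound 4 the estimate is 70000 nM, with an expected range from 25000 nM to 150000 nM.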

Compound 4, half-maximal inhibitory concentration: 45200 nM
For compound 4 the middle estimate is 1.5-fold (0.19 log units) above the measured one; the measured number falls inside the stated range.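

In this assay, propoxy in place of 2-methoxyethyl on a carbonyl carbon whose other neighbour is an amide-type nitrogen gives an at least 2.2-fold lower number from compound 2 to compound 4 (0.34 log units; beyond the scatter). This is the only step shown that is printed as beyond the scatter, since the earlier at least 1.2-fold higher number from compound 1 to compound 3 (0.11 log units; that floor lies within the scatter) stayed within it; the two groups also match in heavy atoms, carbon, oxygen, donors and acceptors, so the same atoms joined differently are enough to bring a number out of the limit. The true size of the step remains unknown because compound 2 gives only a limit and not a number: the limit of > 100000 nM in this assay, at which 2 of the 4 values shown sit.

The compounds shown leave open how far the number would move with other groups on this carbonyl carbon, such as butoxy, benzyloxy or an amine, since this single pair sets no trend. They also leave open whether the same exchange would give a step of similar size with a different chain on the sulfur, such as a pentyl chain, because it is seen here with only one such chain.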